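Exchanging the carbonyl-side aryl group in a weak cytotoxic series

This account rests on a few compounds, and the source may have more. Where it says the series, first, only, none or still open, it means among the compounds named here.

Compound 1 `COc1cc(-c2cc(/C=C/C(=O)c3ccc(N)cc3)[nH]n2)cc(OC)c1OC` was tested in a functional assay on A549 cells (Homo sapiens) for inhibition, read by sulforhodamine B assay, with a stated time of 48 h (a higher number here means that more compound is tolerated, a lower number that less compound is tolerated), where compound 1 gives 86500 nM. Two related compounds were measured alongside it. Compound 2 `COc1ccc(-c2cc(/C=C/C(=O)c3cc(OC)c(OC)c(OC)c3)[nH]n2)cc1OC` gives 62400 nM in this assay, and compound 3 `COc1ccc(-c2cc(/C=C/C(=O)c3ccc(N)cc3)[nH]n2)cc1` gives 46900 nM. The three numbers lie within the scatter of one another, and compound 1 sits at one end of that narrow spread, so no ranking among them can be drawn from these data.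

Compound 4 `COc1ccc(C(=O)/C=C/c2cc(-c3cc(OC)c(OC)c(OC)c3)n[nH]2)cc1OC` has not been measured in this assay. Compared with compound 1 it carries 3,4-dimethoxyphenyl in place of 4-aminophenyl on a carbonyl carbon. Within the data shown here, since no single-point step between measured compounds exists in this set, any expectation for compound 4 must rest on the cluster as a whole, in which a trimethoxyphenyl and an aminophenyl on the carbonyl carbon gave numbers for compound 2 and compound 3 no farther apart than the scatter.

Compound 4 is therefore expected to stay within that cluster, and the step of a 1.2-fold lower number from compound 1 to compound 4 (0.09 log units; within the scatter) is estimated to be no larger than the scatter, in either direction. The estimate for compound 4 in this assay is 70000 nM, with a range from 30000 nM to 160000 nM.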

Compound 4, concentration lethal to 50% of the cells: 15700 nM
Compound 4: the middle estimate sits 4.5-fold (0.65 log units) above what was measured, outside the stated range (below it).
By their numbers in this assay, from the lowest: compound 4; then compounds 3, 2 and 1 (each within the scatter of the next).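

Among these compounds, the exchange at the carbonyl carbon gives the first step in this set that rests on a single change: in this assay, 3,4-dimethoxyphenyl in place of 4-aminophenyl gives a 5.5-fold lower number from compound 1 to compound 4 (0.74 log units; beyond the scatter) with the rest of the structure held constant. The step lies beyond the scatter, so this position is not indifferent to the aryl group it carries, although the effect is modest and compound 4 still gives 15700 nM in this assay. No measurement is available that would explain this difference between the two aryl groups.

Among the compounds shown here, the single pair leaves open whether the step follows the loss of the amine, the arrival of the two methoxy groups, or both together, as these changes occur at once in compound 4. Also open, from the compounds shown here alone, is how a plain phenyl, a 4-hydroxyphenyl or a 4-carboxyphenyl on the same carbonyl carbon would read in this assay, and whether the step would keep its size on a core carrying a different aryl group at the far end.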